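The source may hold more compounds than are shown below. What is called first, only, known or untested is meant among the compounds shown, and "the series" means these compounds.

Compound 1 `O=C1C(=O)N(CCCCn2cc(COc3cc(=O)oc4ccccc34)nn2)c2ccc(F)cc21` is tested in a functional assay on PC-3 cells (Homo sapiens) for inhibition, read by sulforhodamine B assay, with a stated time of 48 h, tested at 50 uM (on this read-out higher numbers stand for more inhibition of growth at the one concentration tested and lower numbers for less inhibition of growth), where compound 1 gives 17%. That is the largest of the three numbers in hand, yet neither neighbour is separated from it beyond the scatter: compound 3 `O=C1C(=O)N(CCCn2cc(COc3cc(=O)oc4ccccc34)nn2)c2ccc(Br)cc21` gives 14% in this assay, and compound 2 `O=C1C(=O)N(CCCCCn2cc(COc3cc(=O)oc4ccccc34)nn2)c2ccccc21` gives 9% in this assay. Within the data shown here, no single-change step between measured compounds is available, so the three numbers only show a flat picture.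

Compound 4 `O=C1C(=O)N(CCCCn2cc(COc3cc(=O)oc4ccccc34)nn2)c2ccc(I)cc21` differs from compound 1 by iodo in place of fluoro on an aromatic carbon. Among the measured compounds shown here, with no comparable step to lean on, the expected change for this assay from compound 1 to compound 4 is a number 1 percentage points higher from compound 1 to compound 4 (within the scatter), none beyond the scatter. Compound 4 is therefore estimated at 18% in this assay, within 6% to 32%.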

Compound 4, percent growth inhibition at one concentration: 10%
Compound 4: the middle estimate sits 8 percentage points above what was measured; measured number inside the range.
By their numbers in this assay, from the lowest: compounds 2, 4, 3 and 1 (each within the scatter of the next).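

In this assay, among these compounds, iodo in place of fluoro on this aromatic carbon gives the first single-change step, a number 7 percentage points lower from compound 1 to compound 4 (within the scatter), which stays within the scatter. At this place, para to a fused ring, the exchange of fluoro for iodo therefore does not separate the two compounds, so the flat picture now holds across a change made in one place. No measurement at hand bears on this result. The compounds shown leave open what an amine or a carboxylic acid on this aromatic carbon would do, and whether any group there moves the number beyond the scatter.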